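The source may hold more compounds than are shown below. What is called first, only, known or untested is meant among the compounds shown, and "the series" means these compounds.

Compound 1 `CC(O)(C(=O)Nc1ccc(S(=O)(=O)N2CCNCC2)cc1)C(F)(F)F`: > 30000 nM
Compound 2 `CC(O)(C(=O)Nc1ccc(S(N)(=O)=O)cc1)C(F)(F)F`: 12800 nM

Both compounds share one core and differ only at the sulfonyl sulfur. In an assay on a protein complex (Cavia porcellus) with sulfonylurea receptors; K-ATP channels (Homo sapiens) as the target (on this read-out lower numbers stand for stronger inhibition and higher numbers for weaker inhibition), compound 1 gives > 30000 nM, which is a limit of the assay rather than a number. Compound 2 gives 12800 nM in this assay, the only number shown among the two compounds. For the measured compounds named here, the one measured step, an at least 2.3-fold lower number from compound 1 to compound 2 (0.36 log units; beyond the scatter), ran toward stronger inhibition, although its size is known only as a bound because compound 1 sits at the limit of > 30000 nM in this assay, at which 1 of the 2 values shown sits.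

Compound 3 `CC(O)(C(=O)Nc1ccc(S(=O)(=O)N2CCCC2)cc1)C(F)(F)F` differs from compound 2 by pyrrolidin-1-yl in place of amino on a sulfonyl sulfur. This is the reverse kind of change to the one measured, with a ring again entering on the sulfonyl sulfur, though a different ring. The step from compound 1 to compound 2 bears on it and suggests the number should rise again, so a modest step toward weaker inhibition is expected in this assay, a 2.0-fold higher number from compound 2 to compound 3 (0.29 log units; within the scatter). Compound 3 is therefore estimated at 25000 nM, in the range 8000 nM to 80000 nM, with a real chance that only a limit is reported.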

Compound 3, half-maximal inhibitory concentration: 880 nM
Compound 3: the middle estimate sits 28-fold (1.45 log units) above what was measured; the measured number lies below the stated range.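

In this assay, the sulfonyl sulfur proves far more sensitive to what it carries than the earlier pair could show: pyrrolidin-1-yl in place of amino gives a 15-fold lower number from compound 2 to compound 3 (1.16 log units; beyond the scatter), toward stronger inhibition. A ring on this sulfur does not in itself go with weaker inhibition, since the two ring-bearing compounds stand far apart, with an at least 34-fold lower number from compound 1 to compound 3 (1.53 log units; beyond the scatter). The size of that step is only a bound, as the value of compound 1 is a limit of the assay: the limit of > 30000 nM in this assay, at which 1 of the 3 values shown sits.

The compounds shown leave open whether the ring itself matters or only the carbon atoms it brings, which an open-chain diethylamino group or a piperidin-1-yl or morpholin-4-yl ring on the same sulfur would help to separate. From the compounds shown here alone, the rest of the shared core stays constant throughout, so the effect of a methyl group in place of the trifluoromethyl also remains unknown.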